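A chloro added to compound 2

A few compounds are considered here, and "the series" means these few. Any claim that something is new, unique, unknown or untested is made for them only; others in the source may bear on it.

In an ADME assay on microsomes from liver (Mus musculus) for metabolic stability, read by LC-MS, using NADPH, tested at 1 uM (on this read-out lower numbers stand for a shorter-lived compound and higher numbers for a longer-lived compound), compound 1 (`Nc1nc(-c2cccc(Cl)c2)c(C(=O)c2ccccc2Cl)s1`) gives 0.0317 h and compound 2 (`Nc1nc(-c2cccc(C(F)(F)F)c2)c(C(=O)c2ccccc2Cl)s1`) gives 0.0483 h. Among the measured compounds shown here, compound 2 therefore stands within the scatter of compound 1, the only other compound measured, and neither can be called the longer-lived. Compound 3 (`Nc1nc(-c2cc(Cl)cc(C(F)(F)F)c2)c(C(=O)c2ccccc2Cl)s1`) keeps the trifluoromethyl group of compound 2 and gains one further group: chloro in place of hydrogen on an aromatic carbon. In words, this is chloro in place of hydrogen on an aromatic carbon, meta to a trifluoromethyl group.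

For the measured compounds named here, only one measured step bears on this change, and it does so indirectly. Trifluoromethyl in place of chloro on an aromatic carbon gave a 1.5-fold higher number from compound 1 to compound 2 (0.18 log units; within the scatter). Going by the values given here, that step exchanges one group for another, whereas compound 3 adds a group, and no measured compound carries both. On this slender evidence, no step beyond the scatter is expected in this assay, in either direction. The estimate amounts to a 1.0-fold higher number from compound 2 to compound 3 (0.02 log units; within the scatter), an expected step that stays small. For compound 3, the half-life is expected to be 0.05 h, with an estimated range of 0.022 h to 0.11 h.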

Compound 3, half-life: 0.102 h
For compound 3 the middle estimate is 2.0-fold (0.31 log units) below the measured one, and the stated range covers the measured number.
By their numbers in this assay, from the lowest: compounds 1 and 2 (each within the scatter of the next); then compound 3.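

In this assay, among the compounds shown here, chloro in place of hydrogen on an aromatic carbon, meta to a trifluoromethyl group, gives a 2.1-fold higher number from compound 2 to compound 3 (0.32 log units; beyond the scatter), the first step to lie beyond the scatter. Keeping that chloro and adding a trifluoromethyl group gives a 3.2-fold higher number from compound 1 to compound 3 (0.51 log units; beyond the scatter), so carrying both groups on the ring stands apart from carrying either one alone, whereas exchanging one group for the other had shown no step beyond the scatter. Compound 3 therefore has the highest number of the three, with its steps to both others beyond the scatter, although both steps are modest.

Nothing shown here explains what lies behind this rise in half-life. It also stays open whether the rise belongs to chloro in particular or would also come with a fluoro, a methoxy or an amine at this place, and whether it would hold if the chloro on the benzoyl ring of these compounds were changed.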